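Changing the amine side chain of compound 3

A few compounds are considered here, and "the series" means these few. Any claim that something is new, unique, unknown or untested is made for them only; others in the source may bear on it.

Measured in a functional assay on Caco-2 cells (Homo sapiens), read by MTT assay, with a stated time of 48 h; a higher number here means a weaker inhibitor, a lower number a stronger inhibitor:
compound 1 `CCN(CC)CCNC(=O)c1ccc(C(CC)(CC)c2ccc(OCC(=O)C(C)(C)C)c(C)c2)n1CC`: 1600 nM
compound 2 `CCn1c(C(=O)NCCN(C)C)ccc1C(CC)(CC)c1ccc(OCC(=O)C(C)(C)C)c(C)c1`: 1600 nM
compound 3 `CCN(CC)CCNC(=O)c1ccc(C(CC)(CC)c2ccc(OCC(O)C(C)(C)C)c(C)c2)n1CC`: 2310 nM

In this assay compound 3 gives 2310 nM, within the scatter of both other compounds. Compound 4 `CCn1c(C(=O)NCCCN(C)C)ccc1C(CC)(CC)c1ccc(OCC(O)C(C)(C)C)c(C)c1` differs from it by (dimethylamino)methyl in place of diethylamino on a saturated chain carbon, two bonds along the chain from an amide-type nitrogen. The closest measured change is no change at the digits printed from compound 1 to compound 2 (within the scatter), which swaps diethylamino for dimethylamino alone. The other measured change, a 1.4-fold higher number from compound 1 to compound 3 (0.16 log units; within the scatter), lies elsewhere in the molecule. Within the data shown here, no measured pair tests 3-(dimethylamino)propyl directly, so the estimate is uncertain. The expected change is a 1.2-fold lower number from compound 3 to compound 4 (0.06 log units; within the scatter), none beyond the scatter. Compound 4 is expected at 2000 nM, with an estimated range of 1000 nM to 4000 nM.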

Compound 4, half-maximal inhibitory concentration: 1900 nM
Compound 4: middle estimate off by 1.1-fold (0.02 log units), on the high side, and the stated range covers the measured number.
By their numbers in this assay, from the lowest: compounds 1, 2, 4 and 3 (each within the scatter of the next).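

The step from 2-(diethylamino)ethyl to 3-(dimethylamino)propyl gives a 1.2-fold lower number from compound 3 to compound 4 (0.08 log units; within the scatter) in this assay, so this position accepts a longer chain together with a dimethylamino group without leaving the scatter. The earlier step at this position changed only the amine, with the (tert-butyl)carbonyl group in place, whereas this one holds with the 1-hydroxy-2,2-dimethylpropyl group. Nothing available explains this result. On these data alone, whether a morpholine, a piperidine or a 4-(dimethylamino)butyl chain would also stay within the scatter remains open. So does the effect of 3-(dimethylamino)propyl alongside the (tert-butyl)carbonyl group.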